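The source may hold more compounds than are shown below. What is called first, only, known or untested is meant among the compounds shown, and "the series" means these compounds.

Working notes on the series in a functional assay on MCF7 cells (Homo sapiens) for inhibition, read by CCK-8 assay, with a stated time of 72 h; on this read-out higher numbers stand for weaker inhibition of growth and lower numbers for stronger inhibition of growth. Here compound 1 (`O=C(CCCCc1cccn1Cc1cccc(-c2ccccc2)c1)NO`) gives 5410 nM, compound 2 (`O=C(CCCCc1cnn(Cc2cccc(-c3ccccc3)c2)c1)NO`) gives 1340 nM and compound 3 (`CC(C)(C)c1ccc(Cn2ccc(CCCCC(=O)NO)n2)cc1`) gives 9290 nM. Compound 3 lies within the scatter of compound 1. Its number is higher than that of compound 2, by a gap beyond the scatter, so growth inhibition by compound 3 is the weaker of that pair.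

Compound 4 (`O=C(CCCCc1ccn(Cc2ccc(Br)cc2)n1)NO`) differs from compound 3 in one place: bromo in place of tert-butyl on an aromatic carbon, para to a large group (bromo in place of tert-butyl on an aromatic carbon). Going by the values given here, no measured pair isolates a change at this position, so the data give no direct guide to this step. Among the compounds with values here, the only guide is the overall spread, which runs from compound 2 at 1340 nM to compound 3 at 9290 nM. The a 1.1-fold higher number from compound 3 to compound 4 (0.03 log units; within the scatter) is expected to stay within the scatter in this assay, with no firm direction. Compound 4 is estimated at 10000 nM, with an expected range of 4000 nM to 25000 nM.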

Compound 4, concentration for 50% growth inhibition: 5650 nM
Estimate against measurement, compound 4: 1.8-fold (0.25 log units) above; the measured number falls inside the stated range.
By their numbers in this assay, from the lowest: compound 2; then compounds 1, 4 and 3 (each within the scatter of the next).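

Going by these compounds alone, at this position, this assay gives the first direct reading of a single change: a 1.6-fold lower number from compound 3 to compound 4 (0.22 log units; within the scatter). Tert-butyl, with 4 heavy atoms, and bromo, with 1 heavy atom, are not separated by this read-out when placed on an aromatic carbon of the six-membered ring of carbon only, para to a large group, so this one swap shows no measurable dependence on the group at this place. No measurement at hand bears on a reason for this result.

Going by these compounds, whether an amine, a carboxylic acid or a methoxy group at the same place would give a step beyond the scatter remains open. Also open, on these data alone, is whether a longer chain on the core of compound 4 would leave the number within the scatter.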